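This account rests on a few compounds, and the source may have more. Where it says the series, first, only, none or still open, it means among the compounds named here.

Of the compounds shown here, two with the same core have been measured in an assay on isolated protein for binding affinity to Equilibrative nucleoside transporter 1 (Homo sapiens) (a lower number here means a stronger inhibitor, a higher number a weaker inhibitor), so far. Compound 1 `Cc1cccc(CSc2ncnc3c2ncn3[C@@H]2O[C@H](CO)[C@@H](O)[C@H]2O)c1` gives 12000 nM. Among the compounds with values here, compound 2 `OC[C@H]1O[C@@H](n2cnc3c(CSc4ccc(Br)cc4)ncnc32)[C@H](O)[C@@H]1O` gives 178 nM, the lowest of the two numbers; the only measured step, a 67-fold lower number from compound 1 to compound 2 (1.83 log units; beyond the scatter), is a large one and separates compound 2 from compound 1 by a wide margin.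

The next compound to consider is compound 3 `OC[C@H]1O[C@@H](n2cnc3c(CSc4ccc(OC(F)(F)F)cc4)ncnc32)[C@H](O)[C@@H]1O`. It differs from compound 2 by trifluoromethoxy in place of bromo on an aromatic carbon, the change sitting on an aromatic carbon of a six-membered aromatic ring of carbon only, para to a large group. Within the data shown here, no measured step bears directly on this exchange: the one step on record, a 67-fold lower number from compound 1 to compound 2 (1.83 log units; beyond the scatter), changed both the link and the ring at once, so it says nothing about swapping one substituent on the ring for another. With only compound 2 as a reference, the expectation is a step of a 1.4-fold higher number from compound 2 to compound 3 (0.15 log units; within the scatter), that is, little movement beyond the scatter in either direction. Compound 3 is therefore estimated at 250 nM in this assay, within a range of 80 nM to 800 nM.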

Compound 3, half-maximal inhibitory concentration: 123 nM
Compound 3: middle estimate off by 2.0-fold (0.31 log units), on the high side; the range from low to high includes it.
By their numbers in this assay, from the lowest: compounds 3 and 2 (each within the scatter of the next); then compound 1.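

In this assay, putting trifluoromethoxy in place of bromo on this aromatic carbon, para to a large group, gives a 1.4-fold lower number from compound 2 to compound 3 (0.16 log units; within the scatter), so the two groups cannot be told apart here. The earlier step changed the link and the ring together and could say nothing about a single substituent on the ring. This comparison isolates that one place: a group of 5 heavy atoms, including 1 hydrogen-bond acceptor, reads the same as a single bromine atom, and the number stays within the scatter, so this position tolerates at least these two quite different groups, and there is no measured information to explain why they read alike.

As far as these compounds go, these two groups both carry no hydrogen-bond donor and no net charge, so it remains open whether an amine, a carboxylic acid or a hydroxyl group at the same carbon would leave the number just as unmoved. From the compounds shown here alone, it is also open how much of the large step from the earlier pair comes from the link and how much from the ring substituent, since a compound changing only one of them would be needed to separate the two.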